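Halogen exchange at the aryl ring: compound 3 to compound 4

The source may report more compounds than this note shows. Statements on the series, on what has been measured and on what is new or still open speak of the compounds shown alone.

Measured so far in an assay on cell membranes for displacement of a labelled ligand from Neuronal acetylcholine receptor; alpha4/beta2 (Rattus norvegicus), read by radioligand binding, with a stated time of 30 min; a higher number here means a weaker inhibitor, a lower number a stronger inhibitor:
compound 1 `OCc1cccc(C2=NCCCC2)c1` gives 35000 nM
compound 2 `Fc1cccc(C2=NCCCC2)c1` gives 2040 nM
compound 3 `Ic1cccc(C2=NCCCC2)c1` gives 3790 nM

Compound 3 holds the second highest of the three numbers. Its nearest neighbour is compound 2: the step of a 1.9-fold higher number from compound 2 to compound 3 (0.27 log units; within the scatter) stays within the scatter, so the two halogen analogues are not separated here. The furthest is compound 1, and the step of a 9.2-fold lower number from compound 1 to compound 3 (0.97 log units; beyond the scatter) is clear; the parallel step a 17-fold lower number from compound 1 to compound 2 (1.23 log units; beyond the scatter) is likewise clear and somewhat larger.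

Compound 4 `Clc1cccc(C2=NCCCC2)c1` differs from compound 3 by chloro in place of iodo on an aromatic carbon. Going by the values given here, the one measured step that bears directly on a halogen-for-halogen exchange is a 1.9-fold higher number from compound 2 to compound 3 (0.27 log units; within the scatter), which lies within the scatter. The two larger steps, from compound 1 to compound 2 and from compound 1 to compound 3, involve loss of hydroxymethyl and do not apply to a change among halogens. Chloro sits between fluoro and iodo in what it brings, and there is no indication from these three compounds that it would move the number beyond the scatter in either direction.

For compound 4 in this assay the expected value is therefore 2600 nM, with a range of 1200 nM to 5500 nM, corresponding to an estimated step of a 1.5-fold lower number from compound 3 to compound 4 (0.16 log units; within the scatter).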

Compound 4, inhibition constant: 11500 nM
The estimate for compound 4 lay 4.4-fold (0.65 log units) below the measured number, outside the stated range (above it).
By their numbers in this assay, from the lowest: compounds 2 and 3 (each within the scatter of the next); then compound 4; then compound 1.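

Notes on the halogen series: in this assay the halogens on this aromatic carbon are not interchangeable, which the earlier fluoro and iodo pair could not show. Chloro in place of iodo gives a 3.0-fold higher number from compound 3 to compound 4 (0.48 log units; beyond the scatter) and chloro in place of fluoro gives a 5.6-fold higher number from compound 2 to compound 4 (0.75 log units; beyond the scatter), so compound 4 stands apart from both other halogen analogues, while those two remain within the scatter of each other. Going by these compounds alone, the number therefore does not run in order down the halogens, with fluoro, chloro and iodo as the only three cases and compound 4 the one that breaks such a run. Hydroxymethyl still gives the highest number of the four groups, since chloro in its place gives a 3.0-fold lower number from compound 1 to compound 4 (0.48 log units; beyond the scatter) and the steps to fluoro and iodo are also beyond the scatter.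

No measurement at hand accounts for chloro standing apart from fluoro and iodo. As far as these compounds go, it remains open how a methoxy, a trifluoromethyl, an amine or a carboxylic acid on the same aromatic carbon would stand against these halogens, and whether the chloro result holds at other places on the ring.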